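This account rests on a few compounds, and the source may have more. Where it says the series, first, only, none or still open, it means among the compounds named here.

Working notes on the series. Compound 1 `OC1C#CCCCCC#C/C1=C\c1cccc2ccccc12` carries a free hydroxyl on a saturated ring carbon; compound 2 `CC(=O)OC1C#CCCCCC#C/C1=C\c1cccc2ccccc12` is its acetate. In a functional assay on P388 cells (Mus musculus) for inhibition, read by MTT assay (a lower number here means a stronger inhibitor, a higher number a weaker inhibitor), compound 1 gives 41000 nM. In this assay compound 2 gives 2400 nM. Within the data shown here, the single measured step, a 17-fold lower number from compound 1 to compound 2 (1.23 log units; beyond the scatter), is the only one in hand. Among the measured compounds shown here, compound 2 therefore stands at the lowest of the two numbers so far, with compound 1 as its only neighbour, a gap that is beyond the scatter.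

Compound 3 `COCC(=O)OC1C#CCCCCC#C/C1=C\c1cccc2ccccc12` is not yet measured. Against compound 2 the change is methoxy in place of hydrogen on a saturated chain carbon bound to a carbonyl carbon, so the acetyl becomes a (methoxymethyl)carbonyl and the acetoxy a ((methoxymethyl)carbonyl)oxy. For the measured compounds named here, no measured step touches that chain carbon: the one step known, a 17-fold lower number from compound 1 to compound 2 (1.23 log units; beyond the scatter), concerns ester versus free hydroxyl, which compound 3 keeps. With the ester retained and nothing measured on the chain itself, the step of a 1.0-fold higher number from compound 2 to compound 3 (0.02 log units; within the scatter) is expected to stay within the scatter, direction undetermined. Compound 3 in this assay is thus expected near 2500 nM, within a range from 900 nM to 7000 nM.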

Compound 3, half-maximal inhibitory concentration: 12000 nM
Compound 3: middle estimate off by 4.8-fold (0.68 log units), on the low side; measured number outside the range, above it.
By their numbers in this assay, from the lowest: compound 2; then compound 3; then compound 1.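

The saturated chain carbon bound to a carbonyl carbon is not a silent position: in this assay methoxy in place of hydrogen there gives a 5.0-fold higher number from compound 2 to compound 3 (0.70 log units; beyond the scatter) and so the number depends on the acyl group, not only on the presence of an ester. The (methoxymethyl)carbonyl ester still stands apart from the free hydroxyl, with a 3.4-fold lower number from compound 1 to compound 3 (0.53 log units; beyond the scatter) as its step, so this change gives back part of what the acetyl gained without returning to the level of compound 1. No evidence in hand bears on why methoxy at this place moves the number in this direction.

The compounds shown leave open whether the higher number belongs to the methoxy itself or to any replacement of hydrogen on that chain carbon, which a hydroxyl, an amine or a plain ethyl group at the same place would help to separate. Also open, as far as these compounds go, is how a longer chain or a carboxylic acid on the acyl group would read in this assay against the acetate and the methoxy ester.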